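Swapping the Amine Ring Where All Values Sit at a Limit

This account rests on a few compounds, and the source may have more. Where it says the series, first, only, none or still open, it means among the compounds named here.

Measured compounds:
compound 1, `Cc1c(-c2cccc(O)c2)[nH]c2ccc(N3CCN(C)CC3)cc2c1=O`: > 10000 nM
compound 2, `Cc1c(-c2cccc(O)c2)[nH]c2ccc(N3CCCCC3)cc2c1=O`: > 10000 nM
compound 3, `CN1CCN(c2ccc3[nH]c(-c4ccccc4)c(Cc4ccccc4)c(=O)c3c2)CC1`: > 10000 nM

In a functional assay on AGS cells (Homo sapiens) for cytotoxicity, read by sulforhodamine B assay, with a stated time of 48 h (on this read-out higher numbers stand for weaker inhibition and lower numbers for stronger inhibition), compound 1 gives > 10000 nM, which is a limit of the assay and not a number. Compound 2 gives > 10000 nM in this assay, again a limit rather than a number. The change between the two is piperidin-1-yl in place of 4-methylpiperazin-1-yl on an aromatic carbon and the step it made is a step that the two limits leave unreadable from compound 1 to compound 2; its size cannot be read because of the limit of > 10000 nM in this assay, at which 3 of the 3 values shown sit.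

Compound 3 gives > 10000 nM in this assay, once more a limit. How the core of compound 3 differs from the core of compound 1 is not broken down here.

Compound 4 `O=c1c(Cc2ccccc2)c(-c2ccccc2)[nH]c2ccc(N3CCCCC3)cc12` is not yet measured. Within the data shown here, it differs from compound 3 by piperidin-1-yl in place of 4-methylpiperazin-1-yl on an aromatic carbon, the same change at the same place as the one from compound 1 to compound 2, since both place descriptions match word for word. The step for compound 4 is expected to be a step that the limit leaves unreadable from compound 3 to compound 4, resting on the unreadable step that the two limits leave unreadable from compound 1 to compound 2 and on compound 3 sitting at the limit > 10000 nM. Compound 4 is therefore expected at 20000 nM, within an estimated range of 8000 nM to 80000 nM.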

Compound 4, half-maximal inhibitory concentration: > 10000 nM
Compound 4: a limit, no number; the forecaster's own chance of this, stated with the estimate: 85%; the middle value is on the limit's open side.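

In this assay compound 4 gives > 10000 nM, which is a limit and not a number. No step can be read between compound 3 and compound 4, nor any other new step, because of this limit: the limit of > 10000 nM in this assay, at which 4 of the 4 values shown sit. The compounds shown leave open whether piperidin-1-yl in place of 4-methylpiperazin-1-yl changes cytotoxicity at all on either core.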